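The source may hold more compounds than are shown below. What is called first, only, known or untested is meant among the compounds shown, and "the series" means these compounds.

Three compounds share one core and differ only in the aryl group on the sulfonamide nitrogen. In an assay on isolated protein for inhibition of Nicotinamide phosphoribosyltransferase (Homo sapiens), read by WST assay, with stated times of 60 min, 5 min and 30 min, in the presence of a further agent that is not named here (on this read-out higher numbers stand for weaker inhibition and lower numbers for stronger inhibition), compound 1 `Cc1ccc(NS(=O)(=O)c2cccc(CCCCCCNC(=O)/C=C/c3cccnc3)c2)cc1` gives 9.78 nM. Compound 2 `Cc1ccc(C)c(NS(=O)(=O)c2cccc(CCCCCCNC(=O)/C=C/c3cccnc3)c2)c1` gives 11.6 nM in this assay, and compound 3 `CC(C)(C)c1ccc(NS(=O)(=O)c2cccc(CCCCCCNC(=O)/C=C/c3cccnc3)c2)cc1` gives 9.47 nM. Compound 3 has the smallest of the three numbers, but the gaps are slight: a 1.0-fold lower number from compound 1 to compound 3 (0.01 log units; within the scatter) and a 1.2-fold lower number from compound 2 to compound 3 (0.09 log units; within the scatter), while a 1.2-fold higher number from compound 1 to compound 2 (0.07 log units; within the scatter) is equally slight. Compound 4 `O=C(/C=C/c1cccnc1)NCCCCCCc1cccc(S(=O)(=O)Nc2ccc(Cl)cc2)c1` is the next variation at that same aryl group: chloro in place of tert-butyl on an aromatic carbon. Among the measured compounds shown here, every step seen so far at that site has stayed within the scatter, and none of the measured compounds carries a halogen there, so the expectation rests on that record alone. The expected step is a 1.1-fold higher number from compound 3 to compound 4 (0.02 log units; within the scatter), that is, nothing beyond the scatter. In this assay compound 4 is estimated to give 10 nM, within a range from 5 nM to 20 nM.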

Compound 4, half-maximal inhibitory concentration: 10.8 nM
Compound 4: the middle estimate sits 1.1-fold (0.03 log units) below what was measured; the measured number falls inside the stated range.
By their numbers in this assay, from the lowest: compounds 3, 1, 4 and 2 (each within the scatter of the next).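

In this assay, compound 4 is the only one of the four with a halogen on the aryl group, and replacing tert-butyl, with 4 heavy atoms, by chloro, with 1, gives a step within the scatter (a 1.1-fold higher number from compound 3 to compound 4 (0.06 log units; within the scatter)). The two other comparisons also stay within the scatter, for chloro in place of methyl (a 1.1-fold higher number from compound 1 to compound 4 (0.04 log units; within the scatter)) and for 4-chlorophenyl in place of 2,5-dimethylphenyl (a 1.1-fold lower number from compound 2 to compound 4 (0.03 log units; within the scatter)), so among these four compounds neither the size of the group nor the presence of a halogen produces a step beyond the scatter. Nothing available here explains why the number holds so steady.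

From the compounds shown here alone, it remains open whether an amine or a carboxylic acid on that same aromatic carbon would also stay within the scatter. Going by these compounds, it is equally open whether a plain unsubstituted phenyl would do so.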